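A Benzyl Group on Selenium in a Furoyl Selenourea

The source may report more compounds than this note shows. Statements on the series, on what has been measured and on what is new or still open speak of the compounds shown alone.

Compound 1 `C[Se]/C(=N\C(=O)c1ccco1)NC(=O)c1ccco1` was tested in a functional assay on K562 cells (Homo sapiens) for cytotoxicity, read by MTT assay, with a stated time of 72 h; on this read-out lower numbers stand for stronger inhibition of growth and higher numbers for weaker inhibition of growth. In this assay compound 1 gives only a limit of the assay, > 100000 nM. Compound 2 `O=C(/N=C(/NC(=O)c1csc([N+](=O)[O-])c1)[Se]Cc1ccccc1)c1csc([N+](=O)[O-])c1` is the other measured compound, and in this assay compound 2 gives 55800 nM. Compound 3 `O=C(/N=C(/NC(=O)c1ccco1)[Se]Cc1ccccc1)c1ccco1` is not yet measured; it differs from compound 1 by phenyl in place of hydrogen on a saturated chain carbon bound to a selenium atom. Compound 1 stands at the limit of > 100000 nM in this assay, at which 1 of the 2 values shown sits, so the step to compound 3 can only be read as a move to a real number or as no change. The step of an at least 1.6-fold lower number from compound 1 to compound 3 (0.22 log units; that floor lies within the scatter) is expected to be a move toward stronger inhibition. For compound 3 the estimate is 60000 nM, with a range from 20000 nM to 150000 nM.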

Compound 3, concentration for total growth inhibition: 44200 nM
Compound 3: the middle estimate sits 1.4-fold (0.13 log units) above what was measured; the measured number falls inside the stated range.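

In this assay the change from methyl to benzyl gives an at least 2.2-fold lower number from compound 1 to compound 3 (0.35 log units; beyond the scatter) and so brings this series to a real number at this place, on a saturated chain carbon bound to a selenium atom. Compound 1 gives > 100000 nM as a limit of the assay and not a number, so the step has a floor but no known size. The compounds shown leave open whether a plain longer chain without the phenyl would do the same, and whether an amine or a carboxylic acid on the phenyl would shift the number further.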